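The source may report more compounds than this note shows. Statements on the series, on what has been measured and on what is new or still open speak of the compounds shown alone.

Within the data shown here, compound 2 `Cc1nnc(-c2cccc(-c3ccc(C(=O)N(Cc4cccc(OCCCCCC(=O)O)c4)C(C)C)cc3)c2)o1` is one of only two compounds measured so far in an ADME assay on HEK293 cells (Homo sapiens) for cytotoxicity, read by CellTiter-Glo and resazurin assay, with a stated time of 72 h (on this read-out higher numbers stand for an effect only at larger amounts of compound and lower numbers for an effect already at smaller amounts), and for it the assay returns a limit rather than a number: compound 2 gives > 26000 nM. The other compound, compound 1 `CC(C)N(Cc1cccc(OCCCCCC(=O)O)c1)C(=O)c1ccc(-c2ccoc2)cc1`, likewise sits at a limit; in this assay compound 1 gives > 26000 nM. Among the measured compounds shown here, the single measured step, a step that the two limits leave unreadable from compound 1 to compound 2, therefore carries no readable size in either direction, and the only evidence on the numbers is the limit of > 26000 nM in this assay, at which 2 of the 2 values shown sit, so compound 2 stands at the upper edge of what the assay reports, with nothing to set it apart from compound 1.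

Compound 3 `CC(C)N(Cc1cccc(OCCCCCC(=O)O)c1)C(=O)c1ccc(-c2ccc3[nH]ccc3c2)cc1` is the unmeasured compound. It differs from compound 2 by 1H-indol-5-yl in place of 3-(5-methyl-1,3,4-oxadiazol-2-yl)phenyl on an aromatic carbon. For the measured compounds named here, because the one measured step, a step that the two limits leave unreadable from compound 1 to compound 2, is unreadable, no step of known size bears on this change, and the expectation can rest only on the fact that both measured compounds sit at the limit given in the limit of > 26000 nM in this assay, at which 2 of the 2 values shown sit. It is therefore expected that compound 3 shows no step beyond the scatter, a step that the limit leaves unreadable from compound 2 to compound 3, and compound 3 is estimated at 30000 nM, with a range from 15000 nM to 60000 nM.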

Compound 3, half-maximal effective concentration: > 26000 nM
Compound 3 gave a limit, no number (the forecaster's own chance of this, stated with the estimate: 75%); the middle value is on the limit's open side.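

No size can be read for any step among compound 1, compound 2 and compound 3 in this assay, because all three stop at the same limit: the limit of > 26000 nM in this assay, at which 3 of the 3 values shown sit. The compounds shown leave open where the half-maximal effect of any of them lies, and whether any group on the shared core would bring a readable number.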